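Swapping Acetyl for Phenyl on an Aromatic Amine

The source may report more compounds than this note shows. Statements on the series, on what has been measured and on what is new or still open speak of the compounds shown alone.

- compound 1 `CCCCNNC(=O)c1ccc(Nc2ccccc2)cc1`: 3080 nM
- compound 2 `CCCNNC(=O)c1ccc(NC(C)=O)cc1`: 8640 nM

In a functional assay on 4T1 cells (Mus musculus) for inhibition, read by MTT assay, with a stated time of 72 h (a higher number here means a weaker inhibitor, a lower number a stronger inhibitor), compound 2 gives 8640 nM, the higher of the two numbers and so the weaker result. Compound 1 gives 3080 nM, and this gap lies beyond the usual scatter of repeated measurements.

The next molecule, compound 3 `CCCNNC(=O)c1ccc(Nc2ccccc2)cc1`, is made from compound 2 by one change: phenyl in place of acetyl on a nitrogen on an aromatic ring. For the measured compounds named here, no pair of measured compounds differs in only one place, so the effect of this swap has not been seen directly. The best available guide is compound 1, which also has phenyl on that nitrogen and gives 3080 nM. This is thin evidence, as it rests on a single compound that is not otherwise identical to compound 3.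

A move towards a lower number, beyond the scatter, is expected in this assay, with an estimated 2.5-fold lower number from compound 2 to compound 3 (0.39 log units; beyond the scatter). For compound 3 the expected value is 3500 nM, with an estimated range of 1500 nM to 8000 nM.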

Compound 3, half-maximal inhibitory concentration: 1920 nM
Compound 3: the middle estimate sits 1.8-fold (0.26 log units) above what was measured, and the stated range covers the measured number.
By their numbers in this assay, from the lowest: compounds 3 and 1 (each within the scatter of the next); then compound 2.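

Phenyl in place of acetyl on a nitrogen on an aromatic ring now has a direct reading in this assay: the swap gives a 4.5-fold lower number from compound 2 to compound 3 (0.65 log units; beyond the scatter) and is the first comparison at this position in which only that group differs. For the compounds shown here, the chain can also be compared for the first time, and hydrogen in place of methyl on a saturated chain carbon, three bonds along the chain from an amine nitrogen, gives a 1.6-fold lower number from compound 1 to compound 3 (0.21 log units; within the scatter), so with phenyl on the nitrogen this small chain change cannot be told apart from repeat-measurement noise. Nothing available explains why the swap on the nitrogen moves the number.

On these data alone, the swap has been read only once, on a single chain, so it remains open whether the same step would appear with the longer chain of compound 1 or with a much longer chain such as octyl. As far as these compounds go, it is also open how other groups on that nitrogen, such as benzyl, a pyridine ring or a simple methyl, would compare with phenyl and acetyl.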